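The compounds below may be only part of what the source reports. "The series", "measured", "known", "first", "only" and "open" are said of these compounds alone.

Working notes on the series. Compound 1 `O=C(NCCCCc1ccccc1)c1cccc(C2SCC(=O)N2c2ccc(-c3ccccc3)cc2)c1` is tested in a functional assay on HOS-TE85 cells (Homo sapiens) for inhibition, read by CCK-8 assay, with a stated time of 72 h (a higher number here means a weaker inhibitor, a lower number a stronger inhibitor), where compound 1 gives > 1000 nM; that figure is a limit of the measurement and not a number, so compound 1 stands only at the edge of what the measurement covers (the limit of > 1000 nM in this assay, at which 1 of the 2 values shown sits). Compound 2 `Cc1ccnc(N2C(=O)CSC2c2cccc(C(=O)NCCCCn3cccn3)c2)c1` is the other measured member of the series; in this assay compound 2 gives 19.6 nM. Compound 2 differs from compound 1 in more than one place, and the two values show no more than that one member reaches a measurable potency while the other does not.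

Compound 3 `COc1ccc(N2C(=O)CSC2c2cccc(C(=O)NCCCCc3ccccc3)c2)c(OC)c1` is the next step from compound 1. The change is 2,4-dimethoxyphenyl in place of 4-phenylphenyl on an amide-type nitrogen in a ring. For the measured compounds named here, no step between measured compounds fixes the size of this kind of change. With compound 1 at a limit, the step from compound 1 to compound 3 is given only as an expectation: a move toward a measurable value is expected, an at least 2.5-fold lower number from compound 1 to compound 3 (0.39 log units; beyond the scatter), with a real chance that the result again stays at the limit. Compound 3 is expected to give 400 nM in this assay, within a range of 60 nM to 3000 nM.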

Compound 3, half-maximal inhibitory concentration: 90.4 nM
Beside the measured number, compound 3's estimate is 4.4-fold (0.65 log units) above it; the measured number falls inside the stated range.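

For the compounds shown here, this is the first single-place step: 2,4-dimethoxyphenyl in place of 4-phenylphenyl on the amide-type nitrogen in a ring gives an at least 11-fold lower number from compound 1 to compound 3 (1.04 log units; beyond the scatter) in this assay, so with the rest of compound 1 unchanged, this position alone carries a measurable value. The change replaces 2 six-membered aromatic rings of carbon only and 0 hydrogen-bond acceptors with one such ring and 2 hydrogen-bond acceptors, and this single step cannot separate these differences from one another or assign the gain to either. In this assay compound 1 gives > 1000 nM, a limit and not a number, so the size of the step is known only as a bound: the limit of > 1000 nM in this assay, at which 1 of the 3 values shown sits.

The compounds shown leave open whether both methoxy groups are needed at this position, a question that an unsubstituted phenyl or a phenyl with a single methoxy would address. Compound 2 differs from compound 3 in more than one place, so the steps involving compound 2 cannot be read.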